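A few compounds are considered here, and "the series" means these few. Any claim that something is new, unique, unknown or untested is made for them only; others in the source may bear on it.

The account starts from compound 2 `CC(=O)N1CCN(c2nc(Nc3ccc(C#N)c(C(F)(F)F)c3)nc(Oc3ccnc4ccccc34)n2)CC1`. In a functional assay on DU-145 cells (Homo sapiens) for cytotoxicity, read by sulforhodamine B assay, with a stated time of 48 h (on this read-out higher numbers stand for lower toxicity in this test and lower numbers for higher toxicity in this test), compound 2 gives > 100000 nM, which is a limit of the measurement and not a number. Compound 1 `N#Cc1ccc(Nc2nc(Oc3ccnc4ccccc34)nc(N3CCN(C(c4ccccc4)c4ccc(Cl)cc4)CC3)n2)cc1C(F)(F)F` stands at the same limit, giving > 100000 nM in this assay. Compound 3 `N#Cc1ccc(Nc2nc(Oc3ccnc4ccccc34)nc(N3CCN(c4cccc(C(F)(F)F)c4)CC3)n2)cc1C(F)(F)F` also records a limit in this assay, with > 100000 nM. For the measured compounds named here, because of the limit of > 100000 nM in this assay, at which 3 of the 3 values shown sit, the one comparable step, a step that the two limits leave unreadable from compound 2 to compound 3, cannot be sized, as both of its ends sit at the limit. Compound 2 therefore stands where every value shown stands, at the limit, with no readable gradient around it.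

Compound 4 `N#Cc1ccc(Nc2nc(Oc3ccnc4ccccc34)nc(N3CCN(c4cccc(Cl)c4Cl)CC3)n2)cc1C(F)(F)F` differs from compound 2 as follows: 2,3-dichlorophenyl in place of acetyl on an amine nitrogen in a ring. Going by the values given here, the only measured step that bears on an exchange of this kind is the one from compound 2 to compound 3, and it yielded no size, so there is no measured direction to carry over. Compound 4 is therefore expected to remain at or beyond the same limit, the step that the limit leaves unreadable from compound 2 to compound 4 being expected to fall within scatter. The estimate for compound 4 in this assay is 150000 nM, with a range from 50000 nM to 500000 nM, and most likely another limit rather than a number.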

Compound 4, concentration lethal to 50% of the cells: > 100000 nM
Compound 4 ended at the assay's limit; the forecaster's own chance of this, stated with the estimate: 80%; the middle value is on the limit's open side.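

No size can be read for the steps from compound 2 to compound 4 or from compound 3 to compound 4, because every value now sits at one limit: the limit of > 100000 nM in this assay, at which 4 of the 4 values shown sit.

The compounds shown leave open how the groups on the amine nitrogen in the ring would rank in this assay, as none of them gives a number.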